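Dichlorophenyl to Methoxyphenyl: An Expected Loss of Potency

A few compounds are considered here, and "the series" means these few. Any claim that something is new, unique, unknown or untested is made for them only; others in the source may bear on it.

Compound 1 `NC1=NC2(CCSCC2)N(OCCCOc2ccc(Cl)c(Cl)c2)C(N)=N1`: 1 nM
Compound 2 `NC1=NC2(CCOCC2)N(OCCCOc2ccccc2Cl)C(N)=N1`: 70 nM

In a functional assay on HCT-116 cells (Homo sapiens) for antiproliferative activity, read by MTT assay, with a stated time of 72 h (a lower number here means a stronger inhibitor, a higher number a weaker inhibitor), compound 1 gives 1 nM, the lowest of the two numbers, while compound 2 gives 70 nM, a gap well beyond the scatter. Compound 3 `COc1ccc(OCCCON2C(N)=NC(N)=NC23CCSCC3)cc1` has not yet been measured. It differs from compound 1 in one place: 4-methoxyphenyl in place of 3,4-dichlorophenyl on an oxygen on a saturated carbon. Going by the values given here, no single-change step between measured compounds guides this move, so the expectation rests on compound 1 alone. The step of a 20-fold higher number from compound 1 to compound 3 (1.30 log units; beyond the scatter) is expected to raise the number beyond the scatter, toward a weaker inhibitor. Compound 3 is thus estimated at 20 nM, within a range of 4 nM to 100 nM.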

Compound 3, half-maximal inhibitory concentration: 70 nM
Compound 3: the middle estimate sits 3.5-fold (0.54 log units) below what was measured; the range from low to high includes it.
By their numbers in this assay, from the lowest: compound 1; then compounds 2 and 3 (each within the scatter of the next).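

In this assay the swap of 3,4-dichlorophenyl for 4-methoxyphenyl gives a 70-fold higher number from compound 1 to compound 3 (1.85 log units; beyond the scatter) and is a large step. This place on the compound is therefore sensitive to what the aromatic ring carries, even though both groups count the same number of heavy atoms and hold one six-membered aromatic ring. Nothing measured here gives a cause for the loss. From the compounds shown here alone, the change removes both chlorines and adds a methoxy in one move, and which part matters stays open. A plain phenyl or a 4-chlorophenyl in the same place would help separate the two.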